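This account rests on a few compounds, and the source may have more. Where it says the series, first, only, none or still open, it means among the compounds named here.

In an assay on HEK293 cells for positive allosteric modulation of metabotropic glutamate receptor 2 (Rattus norvegicus), read by thallium flux, with a stated time of 2.5 min (on this read-out higher numbers stand for larger maximal responses and lower numbers for smaller maximal responses), compound 3 `CCCC(=O)c1ccc(OCCCCOc2ccc(C(=O)O)cc2C)c(C)c1O` gives 79.3%. Among the three measured values this stands second highest: compound 2 `Cc1c(OCCCCOc2ccc(C(=O)O)cc2F)ccc(C(=O)CC2CCCC2)c1O` gives 83.8%, a number within the usual scatter of compound 3, while compound 1 `COC(=O)c1ccc(OCCCCOc2ccc(C(=O)CC3CCCC3)c(O)c2C)cc1` gives 12.2%, a far lower number. Compound 4 `Cc1cc(C(=O)O)ccc1OCCCCOc1ccc(C(=O)CC2CCCC2)c(O)c1C` differs from compound 3 by cyclopentyl in place of ethyl on a saturated chain carbon bound to a carbonyl carbon. Among the measured compounds shown here, no measured step touches this part of the molecule; the only measured step, a number 71.6 percentage points higher from compound 1 to compound 2 (beyond the scatter), concerns the other end of the chain and shows only that a compound carrying the cyclopentyl can reach a high maximal response. With no direct guidance, no step beyond the scatter is expected, so compound 4 is estimated at 80%, between 60% and 95%, meaning an expected step of a number 0.7 percentage points higher from compound 3 to compound 4 (within the scatter).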

Compound 4, largest response reached (reported as percent of maximum), in percent of the reference or control that the assay uses: 84.6%
Compound 4: middle estimate off by 4.6 percentage points, on the low side; low and high end bracket the measured number.
By their numbers in this assay, from the lowest: compound 1; then compounds 3, 2 and 4 (each within the scatter of the next).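

In this assay, cyclopentyl in place of ethyl on a saturated chain carbon bound to a carbonyl carbon leaves the response within the scatter (a number 5.3 percentage points higher from compound 3 to compound 4 (within the scatter)), so this position takes either group in these compounds. Methyl in place of fluoro on an aromatic carbon also stays within the scatter (a number 0.8 percentage points higher from compound 2 to compound 4 (within the scatter)), while 4-carboxy-2-methylphenyl in place of 4-(methoxycarbonyl)phenyl repeats the large gain seen with the fluoro analogue (a number 72.4 percentage points higher from compound 1 to compound 4 (beyond the scatter)). No evidence at hand explains these steps. Going by these compounds, whether an amine on that chain carbon, or a much longer chain there, would keep this response remains open.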